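The source may report more compounds than this note shows. Statements on the series, on what has been measured and on what is new or still open speak of the compounds shown alone.

Measured compounds:
- compound 1 `Cc1nc2c3ccccc3ccc2c2nc3c(ccc4ccccc43)c(-c3nccnc3N)c12`: 3560 nM
- compound 2 `COc1ccc(-c2c3ccc4ccccc4c3nc3c2c(C)nc2c4ccccc4ccc32)cc1`: > 80000 nM (a limit)
- compound 3 `Cc1nc2c3ccccc3ccc2c2nc3c(ccc4ccccc43)c(-c3ccccc3Cl)c12`: 48200 nM

In a functional assay on HCT-116 cells (Homo sapiens) for cytotoxicity, read by MTT assay, with a stated time of 48 h (on this read-out lower numbers stand for stronger inhibition and higher numbers for weaker inhibition), compound 3 gives 48200 nM, the highest of the two numbers that are actual numbers, with compound 1 as its nearest neighbour at a 14-fold higher number from compound 1 to compound 3 (1.13 log units; beyond the scatter). For compound 2 the assay reports only a limit, (the limit of > 80000 nM in this assay, at which 1 of the 3 values shown sits), and no number. Compound 4 `Cc1ccc(-c2c3ccc4ccccc4c3nc3c2c(C)nc2c4ccccc4ccc32)cc1` differs from compound 3 in one place: 4-methylphenyl in place of 2-chlorophenyl on an aromatic carbon. Among the measured compounds shown here, two measured steps bear on this. Swapping the 3-aminopyrazin-2-yl group of compound 1 for either phenyl-type group gave a large loss, an at least 22-fold higher number from compound 1 to compound 2 (1.35 log units; beyond the scatter) and a 14-fold higher number from compound 1 to compound 3 (1.13 log units; beyond the scatter), while the exchange of one phenyl-type group for another, an at least 1.6-fold lower number from compound 2 to compound 3 (0.22 log units; that floor lies within the scatter), had a floor lying within the scatter. A 4-methylphenyl group is therefore expected to behave like the other phenyl-type groups, giving for compound 4 a step of a 1.2-fold higher number from compound 3 to compound 4 (0.10 log units; within the scatter) in this assay, that is, no change clearly beyond the scatter. The estimate for compound 4 is 60000 nM, between 20000 nM and 200000 nM.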

Compound 4, half-maximal inhibitory concentration: 67000 nM
Estimate against measurement, compound 4: 1.1-fold (0.05 log units) below; the range from low to high includes it.
By their numbers in this assay, from the lowest: compound 1; then compounds 3 and 4 (each within the scatter of the next). At a limit, above all of these: compound 2.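

In this assay, 4-methylphenyl in place of 2-chlorophenyl on this aromatic carbon gives a 1.4-fold higher number from compound 3 to compound 4 (0.14 log units; within the scatter), so these two phenyl groups, which carry different substituents at different places on the ring, read alike here. The step of a 19-fold higher number from compound 1 to compound 4 (1.27 log units; beyond the scatter) is the third large one away from the 3-aminopyrazin-2-yl group, and it leaves compound 1 alone at the low end of the numbers among the compounds shown. Methyl in place of methoxy gives an at least 1.1-fold lower number from compound 2 to compound 4 (0.07 log units; that floor lies within the scatter), and compound 2 stands only at a limit, so whether these two groups differ stays unsettled: the limit of > 80000 nM in this assay, at which 1 of the 4 values shown sits.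

On these data alone, what remains open is which part of the 3-aminopyrazin-2-yl group goes with the lower number, the amine or the ring nitrogens. An aminophenyl group, or a pyrazinyl group without the amine, would separate the two.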